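Fluorine Added to a Styryl Sulfonamide Anilide

The source may report more compounds than this note shows. Statements on the series, on what has been measured and on what is new or still open speak of the compounds shown alone.

In a functional assay on DU-145 cells (Homo sapiens) for cytotoxicity, read by trypan blue exclusion, with a stated time of 96 h (a lower number here means a stronger inhibitor, a higher number a weaker inhibitor), three compounds have been measured. Compound 1 `COc1ccc(/C=C/S(=O)(=O)Nc2ccc(OC)c(F)c2)cc1` gives 5000 nM in this assay. Compound 2 `COc1ccc(/C=C/S(=O)(=O)Nc2ccc(OC)cc2)cc1` gives 5000 nM in this assay. These two differ in one place, (fluoro in place of hydrogen on an aromatic carbon), and the step of no change at the digits printed from compound 2 to compound 1 (within the scatter) is within the scatter. Compound 3 `COC(=O)C(Nc1cc(NS(=O)(=O)/C=C/c2c(OC)cc(OC)cc2OC)ccc1OC)c1ccccc1` gives 2500 nM in this assay, the lowest of the three numbers, yet its gaps to compound 1 and to compound 2 are each within the scatter, so no order among them can be read. The difference between the core of compound 3 and the core of compound 2 is not broken down here.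

Compound 4 `COC(=O)C(Nc1cc(NS(=O)(=O)/C=C/c2c(OC)cc(OC)cc2OC)ccc1OC)c1ccc(F)cc1` has not been measured. It differs from compound 3 by fluoro in place of hydrogen on an aromatic carbon. This is the same kind of change as that from compound 2 to compound 1, but not the same: there the fluoro sits ortho to a methoxy group and meta to a large group, here it sits para to a large group. Among the compounds with values here, the one measured instance of this kind of change, no change at the digits printed from compound 2 to compound 1 (within the scatter), gives the only ground for an expectation. On that ground the step from compound 3 to compound 4 is estimated as no change at the digits printed from compound 3 to compound 4 (within the scatter) in this assay. Compound 4 is accordingly expected to give about 2500 nM in this assay, with the likely range from 1200 nM to 5500 nM.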

Compound 4, half-maximal inhibitory concentration: 2500 nM
Beside the measured number, compound 4's estimate shows no gap at the digits printed; measured number inside the range.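

In this assay, putting 4-fluorophenyl in place of phenyl on the side arm of the larger core gives no change at the digits printed from compound 3 to compound 4 (within the scatter). Set beside the earlier step on the smaller core, the same kind of change gives the same outcome on both: the same change on two cores in this assay, no change at the digits printed (within the scatter) from compound 2 to compound 1 and no change at the digits printed (within the scatter) from compound 3 to compound 4, 1.0-fold (0.00 log units) apart, within the scatter of two such steps. This shows that, in these two pairs, the swap of hydrogen for fluoro leaves the cytotoxicity reading unmoved on either core, but it does not show that an effect of the change carries from core to core, as there is no effect beyond the scatter to carry, and the fluoro stands in a different setting on each core, so two matching null steps say nothing about other places on these rings or about other cores in the series.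

The compounds shown leave open whether any other group at the same place on the phenyl ring, such as chloro, trifluoromethyl or an amine, would shift the number beyond the scatter where fluoro does not. They also leave open what happens when the methoxycarbonyl group shared by compound 3 and compound 4 gives way to a carboxylic acid or a primary amide.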